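Compound 3: replacing the 1,3-benzothiazol-5-yl group

This account rests on a few compounds, and the source may have more. Where it says the series, first, only, none or still open, it means among the compounds named here.

In a functional assay on MCF7 cells (Homo sapiens) for antiproliferative activity, read by CellTiter-Glo, with a stated time of 5 days (on this read-out higher numbers stand for weaker inhibition and lower numbers for stronger inhibition), compound 1 `O=C(O)/C=C/c1ccc(/C(=C(\c2ccc(F)cc2Cl)C2CCC2)c2ccc3scnc3c2)cc1` gives 3 nM, and compound 2 `O=C(O)/C=C/c1ccc(/C(=C(\c2ncc(C(F)(F)F)cc2Cl)C2CCC2)c2ccc3scnc3c2)cc1` gives 2.9 nM. Going by the values given here, the two values lie within the scatter of each other, so compound 1 stands level with the only other measured member of the series. Compound 3 `O=C(O)/C=C/c1ccc(/C(=C(\c2ccc(F)cc2Cl)C2CCC2)c2ccc3nccn3c2)cc1` differs from compound 1 as follows: a group of 9 heavy atoms (7 carbon, 2 nitrogen; one five-membered aromatic ring with 2 hetero atoms, one six-membered aromatic ring with 1 hetero atom) in place of a group of 9 heavy atoms (7 carbon, 1 nitrogen, 1 sulfur; one five-membered aromatic ring with 2 hetero atoms, one six-membered aromatic ring of carbon only), on a double-bonded chain carbon bound to an aromatic carbon and a double-bonded chain carbon.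

Among the compounds with values here, the one measured step, a 1.0-fold lower number from compound 1 to compound 2 (0.01 log units; within the scatter), lies within the scatter but falls at another place in the molecule. Within the data shown here, it bears only indirectly on this change, and no measured step touches the 1,3-benzothiazol-5-yl group itself. The expected outcome is therefore a small move towards a higher number, with nothing clearly beyond the scatter, though uncertainty is wide. The estimated step is a 1.3-fold higher number from compound 1 to compound 3 (0.12 log units; within the scatter). For compound 3 the expected value is 4 nM, with an estimated range of 1.2 nM to 14 nM.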

Compound 3, half-maximal inhibitory concentration: 4.4 nM
Estimate against measurement, compound 3: 1.1-fold (0.04 log units) below; the range from low to high includes it.
By their numbers in this assay, from the lowest: compounds 2, 1 and 3 (each within the scatter of the next).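

Exchanging the 1,3-benzothiazol-5-yl group for the group in compound 3, on a double-bonded chain carbon bound to an aromatic carbon and a double-bonded chain carbon, gives a 1.5-fold higher number from compound 1 to compound 3 (0.17 log units; within the scatter) in this assay. Sulfur is therefore not needed at this place for this pair: the entering group has no sulfur and carries a hetero atom in its six-membered ring, yet compound 3 stands level with compound 1. Nothing available on these compounds explains why the two groups read alike.

Still open, as far as these compounds go, is whether the same exchange holds alongside the 3-chloro-5-(trifluoromethyl)pyridin-2-yl group of compound 2. Also open, from the compounds shown here alone, is whether a single-ring phenyl group, or a pyridine ring bearing an amine, at this place would stand level with compound 1.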